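Swapping methyl for oxolan-2-yl: effect on liver clearance

A few compounds are considered here, and "the series" means these few. Any claim that something is new, unique, unknown or untested is made for them only; others in the source may bear on it.

Of the compounds shown here, three sharing one core have been tested in an ADME assay on microsomes from liver (Homo sapiens) for metabolic stability, read by LC-MS, using NADPH, with stated times of 10 min and 45 min, tested at 1 uM; a lower number here means slower removal, a higher number faster removal of the compound. Compound 1 `Cc1cc(C)c(CN2CCc3c(Cl)cc(C(CO)c4ccon4)c(Cl)c3C2=O)c(=O)[nH]1` gave 22.7 uL/min; 21.2 uL/min (2 entries), and the repeats are shown in the several entries of compound 1 in this assay, 22.7 uL/min; 21.2 uL/min (2 entries). Compound 2 `COC(c1cc(Cl)c2c(c1Cl)C(=O)N(Cc1c(C)cc(C)[nH]c1=O)CC2)C1CCS(=O)(=O)CC1` gave 15 uL/min; 40 uL/min (2 entries), with the spread of its repeats visible in the several entries of compound 2 in this assay, 15 uL/min; 40 uL/min (2 entries). Among the compounds with values here, compound 3 `Cc1cc(C)c(CN2CCc3c(Cl)cc([C@H](C)CO)c(Cl)c3C2=O)c(=O)[nH]1` gave 15.8 uL/min; this is the only number recorded for it, two further entries having returned no single value. Taken together, the numbers for compound 1, compound 2 and compound 3 sit close to one another, none of them separated from the others by more than the usual scatter of repeated runs.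

Compound 4 `Cc1cc(C)c(CN2CCc3c(Cl)cc([C@@H](CO)[C@H]4CCCO4)c(Cl)c3C2=O)c(=O)[nH]1` has not yet been measured. It differs from compound 3 in one place: oxolan-2-yl in place of methyl on a saturated chain carbon bound to an aromatic carbon and a saturated chain carbon. Within the data shown here, no step between two measured compounds corresponds to this change, so its size cannot be read directly from the data. The spread seen for compound 2 in the several entries of compound 2 in this assay, 15 uL/min; 40 uL/min (2 entries) suggests that a single run can land anywhere within a broad band. For compound 4 the expected step in this assay is a 1.4-fold higher number from compound 3 to compound 4 (0.14 log units; within the scatter), small and within the scatter. Compound 4 is therefore estimated at 22 uL/min, with a likely range from 11 uL/min to 45 uL/min.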

Compound 4, intrinsic clearance in a liver preparation (reported as CLH), per the amount of preparation that the assay uses: 43 uL/min
For compound 4 the middle estimate is 2.0-fold (0.29 log units) below the measured one; measured number inside the range.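

Within the data shown here, this is the first step in the set that can be read directly at this position, the saturated chain carbon bound to an aromatic carbon and a saturated chain carbon: in this assay the change gives a 2.7-fold higher number from compound 3 to compound 4 (0.43 log units; beyond the scatter). The position is therefore not indifferent to what it carries, since replacing methyl with oxolan-2-yl, a larger group with a five-membered non-aromatic ring and a hydrogen-bond acceptor, goes with faster removal in the liver preparation. The step is only modest and rests on a single number for each of its two compounds, and repeats in this set can spread widely, as they do for compound 2: the several entries of compound 2 in this assay, 15 uL/min; 40 uL/min (2 entries)

As far as these compounds go, whether the ring, its oxygen or simply the added size goes with the higher number remains open; a cyclopentyl ring or a butyl chain on the same carbon would help to separate these possibilities. Also open, from the compounds shown here alone, is how this carbon would respond to a group of a different kind, such as an amine or a carboxylic acid, or to the opposite arrangement at the stereocentre of the oxolan-2-yl group.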